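Bromo to Trifluoromethyl on a Triazole-Linked Steroid Scaffold

A few compounds are considered here, and "the series" means these few. Any claim that something is new, unique, unknown or untested is made for them only; others in the source may bear on it.

Measured compounds:
compound 1 `C=C1C[C@]23C[C@@]1(O)CC[C@H]2c1ccc(OS(=O)(=O)c2ccc(C)cc2)c(C)c1[C@@H]3Cn1cc(-c2ccc(Br)cc2)nn1` — > 20000 nM
compound 2 `C=C1C[C@]23C[C@@]1(O)CC[C@H]2c1ccc(O)c(C)c1[C@@H]3Cn1cc(-c2ccc(Br)cc2)nn1` — > 20000 nM
compound 3 `COc1ccc(-c2cn(C[C@H]3c4c(ccc(OS(=O)(=O)c5ccc(C)cc5)c4C)[C@@H]4CC[C@@]5(C)C[C@]43CC5=O)nn2)cc1` — > 20000 nM

The study reads cytotoxicity in a functional assay on MCF7 cells (Homo sapiens) for cytotoxicity, read by MTT assay, with a stated time of 4 days; a higher number here means a weaker inhibitor, a lower number a stronger inhibitor. In this assay compound 1 gives > 20000 nM, which is a limit of the assay and not a number. Compound 2 likewise gives > 20000 nM, again a limit. Compound 3 gives > 20000 nM, also a limit. For the measured compounds named here, all three values therefore sit at the limit of > 20000 nM in this assay, at which 3 of the 3 values shown sit, and the only step between compounds that differ in one place, a step that the two limits leave unreadable from compound 1 to compound 2, cannot be read because both ends are limits.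

Compound 4 `C=C1C[C@]23C[C@@]1(O)CC[C@H]2c1ccc(OS(=O)(=O)c2ccc(C)cc2)c(C)c1[C@@H]3Cn1cc(-c2ccc(C(F)(F)F)cc2)nn1` is not yet measured. It differs from compound 1 by trifluoromethyl in place of bromo on an aromatic carbon, the bromo sitting on an aromatic carbon of a six-membered aromatic ring of carbon only, para to a large group. Going by the values given here, no measured step touches this position or this exchange, so there is nothing among the measured compounds that would point to a change in either direction beyond the scatter. Since compound 1 itself gives only a limit, the expectation for compound 4 is most plainly that it too falls at the limit, and the step from compound 1 to compound 4 is expected to be a step that the limit leaves unreadable from compound 1 to compound 4. The estimate for compound 4 in this assay is 30000 nM, in the range 8000 nM to 120000 nM.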

Compound 4, half-maximal inhibitory concentration: > 20000 nM
Compound 4: a limit, no number; the forecaster's own chance of this, stated with the estimate: 75%; the middle value is on the limit's open side.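

In this assay compound 4 gives > 20000 nM, a limit of the assay and not a number, and compound 1 also stands at a limit, so no step can be read between them for the exchange of bromo for trifluoromethyl. The compounds shown leave open whether any change on the shared core shifts cytotoxicity at all: the limit of > 20000 nM in this assay, at which 4 of the 4 values shown sit.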